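The source may report more compounds than this note shows. Statements on the series, on what has been measured and on what is new or still open speak of the compounds shown alone.

Compound 3 `CC(C)OCC1=CS(=O)(=O)c2ccccc2C1=O` gives 99.2% in a functional assay on the whole organism for inhibition, with Mus musculus as the target, at a dose of 10 mg/kg (a higher number here means more inhibition at the dose given (going by the name of the read-out), a lower number less inhibition), the second highest of the three numbers measured. Its nearest neighbour is compound 2 `COCC1=CS(=O)(=O)c2ccccc2C1=O` with 99.9%, a gap that is within the scatter; the furthest is compound 1 `O=C1C=CS(=O)(=O)c2ccccc21` with 5.5%, a gap of a number 93.7 percentage points higher from compound 1 to compound 3 (beyond the scatter). Compound 4 `O=COCC1=CS(=O)(=O)c2ccccc2C1=O` differs from compound 3 by formyl in place of isopropyl on an oxygen on a saturated carbon. The step that bears on this change is the exchange of one group on the same oxygen, which gave a number 0.7 percentage points lower from compound 2 to compound 3 (within the scatter); the large gains came only where a substituent replaced hydrogen, as in a number 94.4 percentage points higher from compound 1 to compound 2 (beyond the scatter). He therefore expects no step beyond the scatter, an estimated a number 4.2 percentage points lower from compound 3 to compound 4 (within the scatter), and for compound 4 an estimated 95%, between 75% and 100%.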

Compound 4, a percentage reported as inhibition, in the whole organism at one dose (the size of the read-out at that dose, not a potency): 91.6%
Estimate against measurement, compound 4: 3.4 percentage points above; the measured number falls inside the stated range.
By their numbers in this assay, from the lowest: compound 1; then compounds 4, 3 and 2 (each within the scatter of the next).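

Replacing the alkyl group on this oxygen with formyl, which brings a double bond and a hydrogen-bond acceptor, leaves the number in this assay within the scatter, both against isopropyl (a number 7.6 percentage points lower from compound 3 to compound 4 (within the scatter)) and against methyl (a number 8.3 percentage points lower from compound 2 to compound 4 (within the scatter)). So this oxygen carries a carbonyl-bearing group as well as the two alkyl groups, and (formyloxy)methyl in place of hydrogen on the double-bonded ring carbon still gives a large step (a number 86.1 percentage points higher from compound 1 to compound 4 (beyond the scatter)). No evidence is available on what underlies this result. Going by these compounds, whether an amine or a longer chain on this oxygen would hold the number remains open.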